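A few compounds are considered here, and "the series" means these few. Any claim that something is new, unique, unknown or untested is made for them only; others in the source may bear on it.

The compounds share one core and differ only in the aromatic group attached to it. Compound 1 `COc1cc(-c2ccnc3cc(-c4ccc5cc[nH]c5c4)nn23)cc(OC)c1OC` carries a 1H-indol-6-yl there and in a functional assay on A549 cells (Homo sapiens) for inhibition, read by CCK-8 assay, with a stated time of 48 h (on this read-out higher numbers stand for weaker inhibition and lower numbers for stronger inhibition), compound 1 gives 170 nM. Compound 2 `COc1cc(-c2ccnc3cc(-c4ccc(C(F)(F)F)cc4)nn23)cc(OC)c1OC` carries a 4-(trifluoromethyl)phenyl instead, and in this assay compound 2 gives 2070 nM. Compound 3 `CCOC(=O)c1ccc(-c2cc3nccc(-c4cc(OC)c(OC)c(OC)c4)n3n2)cc1` carries an ethoxycarbonyl on that phenyl in place of the trifluoromethyl. For compound 3 the assay reports only a limit, > 10000 nM, as noted in the limit of > 10000 nM in this assay, at which 1 of the 3 values shown sits.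

Among the two numbers given, compound 2 stands at the higher one, with compound 1 as its nearest neighbour: a 12-fold higher number from compound 1 to compound 2 (1.09 log units; beyond the scatter). Toward compound 3 the step is an at least 4.8-fold higher number from compound 2 to compound 3 (0.68 log units; beyond the scatter).

Compound 4 `COc1ccc(-c2cc3nccc(-c4cc(OC)c(OC)c(OC)c4)n3n2)cc1F` is the next variation on compound 2: 3-fluoro-4-methoxyphenyl in place of 4-(trifluoromethyl)phenyl on an aromatic carbon. Both measured steps touch the same position and both were beyond the scatter, one large and one at least modest, so a change of this group can matter considerably. Neither step, however, involves a methoxy or a fluorine on the phenyl, so the direction rests on little. A step of a 2.1-fold lower number from compound 2 to compound 4 (0.32 log units; beyond the scatter) is expected, toward the side of compound 1 rather than compound 3. Compound 4 is therefore estimated at 1000 nM, between 300 nM and 4000 nM.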

Compound 4, half-maximal inhibitory concentration: 545 nM
For compound 4 the middle estimate is 1.8-fold (0.26 log units) above the measured one, within the range that was stated.
By their numbers in this assay, from the lowest: compound 1; then compound 4; then compound 2. At a limit, above all of these: compound 3.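

The earlier compounds shown here showed only that moving away from the 1H-indol-6-yl made the number higher, but compound 4 shows that a phenyl group at this position can also bring it back down. In this assay, replacing 4-(trifluoromethyl)phenyl with 3-fluoro-4-methoxyphenyl gives a 3.8-fold lower number from compound 2 to compound 4 (0.58 log units; beyond the scatter), so the groups on the phenyl ring can shift inhibition in either direction, yet this phenyl does not fully match the indole, as a 3.2-fold higher number from compound 1 to compound 4 (0.51 log units; beyond the scatter) shows. Nothing in the data shown explains why this phenyl group does better than the 4-(trifluoromethyl)phenyl.

The fluorine and the methoxy enter together in compound 4, so the compounds shown cannot tell how much of the step belongs to each of them, and a phenyl carrying only one of the two would be needed to separate them. On these data alone, it also remains open how this position would respond to a phenyl bearing an amine or a carboxylic acid, the latter being the free acid of the ester in compound 3.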